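The source may hold more compounds than are shown below. What is called first, only, known or untested is meant among the compounds shown, and "the series" means these compounds.

Three compounds built on one shared core were tested in a functional assay on A549 cells (Homo sapiens) for cytotoxicity, read by MTT assay; on this read-out lower numbers stand for stronger inhibition and higher numbers for weaker inhibition. Compound 1 `CCc1cc(S(=O)(=O)N2C[C@H](c3ccccc3)NC2=O)ccc1NC(=O)OC` gives 250 nM in this assay. Compound 2 `CCCCOC(=O)Nc1ccc(S(=O)(=O)N2C[C@H](c3ccccc3)NC2=O)cc1CC` gives 200 nM, and compound 3 `CCc1cc(S(=O)(=O)N2C[C@H](c3ccccc3)NC2=O)ccc1NC(=O)OCC(C)C` gives 70 nM. Among these three, compound 3 stands lowest, beyond the scatter from both neighbours: the step of a 3.6-fold lower number from compound 1 to compound 3 (0.55 log units; beyond the scatter) and the step of a 2.9-fold lower number from compound 2 to compound 3 (0.46 log units; beyond the scatter) are both modest but clear, whereas the step of a 1.3-fold lower number from compound 1 to compound 2 (0.10 log units; within the scatter) stays within the scatter.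

Compound 4 `CCc1cc(S(=O)(=O)N2C[C@H](c3ccccc3)NC2=O)ccc1NC(=O)c1ccc(N)cc1` differs from compound 3 in one place: 4-aminophenyl in place of isobutoxy on a carbonyl carbon. Among the compounds with values here, none of the measured steps bears directly on this exchange. All three concern the chain on the saturated carbon bound to the oxygen, and the largest of them, from compound 1 to compound 3, was only modest. Replacing the isobutoxy group with a 4-aminophenyl group removes the oxygen that carried the chain and brings in an aromatic ring and a hydrogen-bond donor, a change of a different kind from those measured, so the direction cannot be read from the data. Compound 4 is therefore expected to give about 300 nM in this assay, within a wide range from 70 nM to 1300 nM. This estimate means a step of a 4.3-fold higher number from compound 3 to compound 4 (0.63 log units; beyond the scatter), expected to go toward a higher number.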

Compound 4, half-maximal inhibitory concentration: 220 nM
Beside the measured number, compound 4's estimate is 1.4-fold (0.13 log units) above it, within the range that was stated.
By their numbers in this assay, from the lowest: compound 3; then compounds 2, 4 and 1 (each within the scatter of the next).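

In this assay, within the data shown here, the carbonyl carbon whose other neighbour is the amide-type nitrogen had so far carried only methoxy, butoxy and isobutoxy, and the change to a ring-bearing group gives a clear loss against the best of these (a 3.1-fold higher number from compound 3 to compound 4 (0.50 log units; beyond the scatter)). Against the other two, the same group cannot be told apart (a 1.1-fold higher number from compound 2 to compound 4 (0.04 log units; within the scatter) and a 1.1-fold lower number from compound 1 to compound 4 (0.06 log units; within the scatter)), so this position accepts 4-aminophenyl, with its aromatic ring and without the oxygen, at the level of butoxy and methoxy, while compound 3 with isobutoxy remains the only one of the four that stands clearly lower than all the others. Nothing measured in this set accounts for either finding.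

The compounds shown leave open whether the amine on the ring has any part in the number of compound 4, which a plain phenyl group or a 4-carboxyphenyl group on the same carbonyl carbon would help to settle. They also leave open whether the lower number of compound 3 belongs to branched chains more widely, as a tert-butoxy or a neopentyloxy group at this place would show.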